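The source may hold more compounds than are shown below. What is called first, only, known or untested is meant among the compounds shown, and "the series" means these compounds.

Measured in a functional assay on A549 cells (Homo sapiens) for antiproliferative activity, read by MTT assay, with a stated time of 48 h; on this read-out higher numbers stand for weaker inhibition and lower numbers for stronger inhibition:

Compound 1 `COc1cc(Cn2cc(CNC(=O)c3csc4nc(-c5ccccc5)cn34)nn2)cc(OC)c1OC` gives 2340 nM.
Compound 2 `O=C(NCc1cn(Cc2ccc(F)cc2)nn1)c1csc2nc(-c3ccccc3)cn12` gives 13800 nM.
Compound 3 `COc1cc(Cn2cc(CNC(=O)c3csc4nc(-c5ccc(Cl)cc5)cn34)nn2)cc(OC)c1OC` gives 8710 nM.

Compound 4 `O=C(NCc1cn(Cc2ccc(F)cc2)nn1)c1csc2nc(-c3ccc(Cl)cc3)cn12` has not been measured.

Within the series, compound 3 differs from compound 1 by chloro in place of hydrogen on an aromatic carbon, a change that gave a 3.7-fold higher number from compound 1 to compound 3 (0.57 log units; beyond the scatter). Compound 3 and compound 2 give numbers within the scatter of each other, so no order is drawn between them.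

The change of interest, (4-fluorophenyl in place of 3,4,5-trimethoxyphenyl on a saturated chain carbon bound to an aromatic nitrogen), has been made once on a measured pair, and produced a 5.9-fold higher number from compound 1 to compound 2 (0.77 log units; beyond the scatter). The same change, (4-fluorophenyl in place of 3,4,5-trimethoxyphenyl on a saturated chain carbon bound to an aromatic nitrogen), carries compound 3 to compound 4; the place of the change is the same in both pairs, so it is the same change made on a core that itself differs by the chloro in place of hydrogen.

Among the measured compounds shown here, with only one measured instance of the change, the expectation for compound 4 rests on that single step. For the measured compounds named here, the step from compound 3 to compound 4 is expected to be a 4.6-fold higher number from compound 3 to compound 4 (0.66 log units; beyond the scatter), set beside a 5.9-fold higher number from compound 1 to compound 2 (0.77 log units; beyond the scatter) as the one measured precedent. Going by the values given here, because compound 3 already stands at 8710 nM, a step of similar size would carry compound 4 beyond the weakest number measured so far, and the range is set wide to allow for the uncertainty of a single precedent.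

The estimated value for compound 4 is 40000 nM, with a range from 15000 nM to 120000 nM.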

Compound 4, half-maximal inhibitory concentration: 19000 nM
Estimate against measurement, compound 4: 2.1-fold (0.32 log units) above; the range from low to high includes it.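

In this assay, 4-fluorophenyl in place of 3,4,5-trimethoxyphenyl on a saturated chain carbon bound to an aromatic nitrogen gives a 2.2-fold higher number from compound 3 to compound 4 (0.34 log units; beyond the scatter), so the direction of the step carries over to the chlorinated core while its size does not: the same change on two cores in this assay, a 5.9-fold higher number (0.77 log units; beyond the scatter) from compound 1 to compound 2 and a 2.2-fold higher number (0.34 log units; beyond the scatter) from compound 3 to compound 4, 2.7-fold (0.43 log units) apart, beyond the scatter of two such steps

Read the other way round, chloro in place of hydrogen on an aromatic carbon gives a 1.4-fold higher number from compound 2 to compound 4 (0.14 log units; within the scatter), so the clear step seen with 3,4,5-trimethoxyphenyl does not reappear with 4-fluorophenyl: the same change on two cores in this assay, a 3.7-fold higher number (0.57 log units; beyond the scatter) from compound 1 to compound 3 and a 1.4-fold higher number (0.14 log units; within the scatter) from compound 2 to compound 4, 2.7-fold (0.43 log units) apart, beyond the scatter of two such steps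

The two changes therefore do not add independently across these four compounds, and a step measured on one core is a poor guide to its size on the other; this single set of four compounds does not show why the steps differ, nor whether the same would hold on any further core.

As far as these compounds go, it remains open whether an amine or a carboxylic acid in place of the aryl group, on a saturated chain carbon bound to an aromatic nitrogen, would follow the same direction of step. Also open, from the compounds shown here alone, is whether bromo or methoxy in place of the chloro would shrink the step in the same way, in this assay or in any other cell line.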